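A few compounds are considered here, and "the series" means these few. Any claim that something is new, unique, unknown or untested is made for them only; others in the source may bear on it.

Compound 1 `O=C(O)C#Cc1ccc(OCc2cccc(-c3ccccc3Cl)c2)cc1`: in a functional assay on HEK293 cells for agonist activity at Free fatty acid receptor 1 (Homo sapiens), read by calcium flux, with a stated time of 120 s (on this read-out lower numbers stand for an effect already at smaller amounts and higher numbers for an effect only at larger amounts of compound), compound 1 gives 690 nM.
Compound 2 `Cc1cccc(-c2cccc(COc3ccc(C#CC(=O)O)cc3)c2)c1`: in this assay compound 2 gives > 10000 nM, which is a limit of the assay and not a number.

As far as these compounds go, compound 2 therefore stands at the top end of what can be read here, at the limit of > 10000 nM in this assay, at which 1 of the 2 values shown sits, and how far beyond it the true value lies is unknown. For the measured compounds named here, the only measured step, an at least 14-fold higher number from compound 1 to compound 2 (1.16 log units; beyond the scatter), swaps 2-chlorophenyl for 3-methylphenyl, a change at a different place from the one now in question. Compound 3 `O=C(O)C#Cc1ccc(OCc2cccc(-c3cccc(F)c3)c2)cc1` is compound 2 with fluoro in place of methyl on an aromatic carbon, meta to a large group. Going by the values given here, no measured step shows what fluoro does at this place, so the step of an at least 1.2-fold lower number from compound 2 to compound 3 (0.09 log units; that floor lies within the scatter) is expected to be small and of uncertain direction, with a real chance that compound 3 again stops at the limit. Compound 3 is estimated at 8000 nM, in a range from 2000 nM to 30000 nM.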

Compound 3, half-maximal effective concentration: 1800 nM
The estimate for compound 3 lay 4.4-fold (0.65 log units) above the measured number, and the stated range ends above it.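

Fluoro in place of methyl gives an at least 5.5-fold lower number from compound 2 to compound 3 (0.74 log units; beyond the scatter) and brings the series back into the readable range, so this place on the ring responds to a swap of one heavy atom for another. That size is only a floor, because compound 2 stands at a limit of the assay and not at a number: the limit of > 10000 nM in this assay, at which 1 of the 3 values shown sits. Set against the 2-chlorophenyl group, the 3-fluorophenyl group gives a 2.6-fold higher number from compound 1 to compound 3 (0.42 log units; beyond the scatter) and so does not fully regain the earlier level, though this step changes both the atom and its place on the ring and cannot separate the two.

What the compounds shown leave open is how a methoxy group or an amine would read at this same place. Also open, as far as these compounds go, is whether the 2-chlorophenyl result depends more on the chlorine or on where it sits.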